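A few compounds are considered here, and "the series" means these few. Any claim that something is new, unique, unknown or untested is made for them only; others in the source may bear on it.

Measured compounds in a functional assay on A549 cells (Homo sapiens) for antiproliferative activity, read by MTT assay, with a stated time of 48 h; a lower number here means a stronger inhibitor, a higher number a weaker inhibitor:
Compound 1 `N#CC1=C(N)Oc2c(c3nc4ccccc4nc3c3ccccc23)C12C(=O)N(Cc1cnnn1-c1cccc(Cl)c1)c1ccccc12` gives 32600 nM.
Compound 2 `N#CC1=C(N)Oc2c(c3nc4ccccc4nc3c3ccccc23)C12C(=O)N(Cc1cnnn1-c1ccc(S(N)(=O)=O)cc1)c1ccccc12` gives > 50000 nM, a limit of the assay.
Compound 3 `Cc1ccc(-n2nncc2CN2C(=O)C3(C(C#N)=C(N)Oc4c3c3nc5ccccc5nc3c3ccccc43)c3ccccc32)cc1C` gives > 50000 nM, a limit of the assay.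

Compound 3 thus stands at the assay ceiling, as does compound 2 (the limit of > 50000 nM in this assay, at which 2 of the 3 values shown sit); only compound 1 returns a number. Compound 4 `Cc1ccc(Cl)cc1-n1nncc1CN1C(=O)C2(C(C#N)=C(N)Oc3c2c2nc4ccccc4nc2c2ccccc32)c2ccccc21` differs from compound 3 by 5-chloro-2-methylphenyl in place of 3,4-dimethylphenyl on an aromatic nitrogen. For the measured compounds named here, the steps that bear on this aryl position are an at least 1.5-fold higher number from compound 1 to compound 2 (0.18 log units; that floor lies within the scatter) and an at least 1.5-fold higher number from compound 1 to compound 3 (0.18 log units; that floor lies within the scatter), both at floors within the scatter, while a step that the two limits leave unreadable from compound 2 to compound 3. Going by the values given here, a chlorine on the phenyl ring accompanied a number in compound 1, but the 2-methyl group of compound 4 has no measured counterpart, so an at least 1.1-fold lower number from compound 3 to compound 4 (0.04 log units; that floor lies within the scatter) is expected to be small or none beyond the scatter. Compound 4 is estimated at 45000 nM, range 18000 nM to 110000 nM, with a limit again likely.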

Compound 4, half-maximal inhibitory concentration: > 50000 nM
Compound 4 gave a limit, no number; the forecaster's own chance of this, stated with the estimate: 55%; at least 1.1-fold (0.04 log units) between middle value and limit.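

With 5-chloro-2-methylphenyl, compound 4 sits at a limit, so a chlorine on the phenyl ring does not by itself go with a number, and compound 1 remains the only compound with one in this assay: the limit of > 50000 nM in this assay, at which 3 of the 4 values shown sit.
The added methyl gives an at least 1.5-fold higher number from compound 1 to compound 4 (0.18 log units; that floor lies within the scatter), a floor and not a measured size. The steps among compound 2, compound 3 and compound 4 cannot be read.

Going by these compounds, whether a carboxylic acid or an amine on this phenyl ring would return a number stays open. On these data alone, how far compound 2, compound 3 and compound 4 lie past the limit also stays open.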